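Cyclopropylsulfonyl in place of pyridin-3-ylsulfonyl

The compounds below may be only part of what the source reports. "The series", "measured", "known", "first", "only" and "open" are said of these compounds alone.

Among the compounds with values here, compound 2 `Cc1ccc2[nH]c(C(=O)N[C@H]3CCN(S(=O)(=O)c4cccnc4)C[C@@H]3C(=O)NCCN(C)C)cc2c1` is one of two compounds measured in a functional assay on HEK293 cells for agonist activity at growth hormone secretagogue receptor type 1 (Homo sapiens), read by HTRF and inositol phosphate accumulation, with a stated time of 90 min, in the presence of a further agent that is not named here; on this read-out higher numbers stand for larger maximal responses and lower numbers for smaller maximal responses. In this assay compound 2 gives 93%; compound 1 `Cc1ccc2[nH]c(C(=O)N[C@H]3CCN(S(=O)(=O)c4ccccc4)C[C@@H]3C(=O)NCCN(C)C)cc2c1` gives 98%, and the two values lie within the scatter of each other, so the numbers show no difference between them. Within the data shown here, the only measured step, a number 5 percentage points lower from compound 1 to compound 2 (within the scatter), is the step that bears on any change at the sulfonyl group, and it was within the scatter. Compound 3 `Cc1ccc2[nH]c(C(=O)N[C@H]3CCN(S(=O)(=O)C4CC4)C[C@@H]3C(=O)NCCN(C)C)cc2c1` differs from compound 2 by the change (cyclopropyl in place of pyridin-3-yl on a sulfonyl sulfur). Among the measured compounds shown here, no measured compound carries a non-aromatic ring on the sulfonyl sulfur, so the measured step covers this change only loosely. Compound 3 is therefore expected to show a number 3 percentage points lower from compound 2 to compound 3 (within the scatter), that is no step beyond the scatter. The estimate for compound 3 is 90%, with a range from 70% to 105%.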

Compound 3, largest response reached (Emax), in percent of the reference or control that the assay uses: 95%
The estimate for compound 3 lay 5 percentage points below the measured number, within the range that was stated.
By their numbers in this assay, from the lowest: compounds 2, 3 and 1 (each within the scatter of the next).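

In this assay, compound 3 extends the comparison on the sulfonyl sulfur from six-membered aromatic rings to a three-membered non-aromatic ring of carbon only. The result is a number 2 percentage points higher from compound 2 to compound 3 (within the scatter) and a number 3 percentage points lower from compound 1 to compound 3 (within the scatter), so the maximal response does not distinguish cyclopropyl from pyridin-3-yl or phenyl in these three compounds, despite the differences in ring type and heavy-atom count. No evidence is available to explain this tolerance.

As far as these compounds go, what an amine, a carboxylic acid or a longer alkyl chain on the same sulfonyl sulfur would do to the maximal response remains open. The values also describe only the largest response reached, so they leave open whether the three sulfonyl substituents differ in the concentration needed to reach it.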